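Three limits and the step to compound 4

The source may report more compounds than this note shows. Statements on the series, on what has been measured and on what is new or still open speak of the compounds shown alone.

In an ADME assay on HepG2 cells (Homo sapiens) for cytotoxicity (on this read-out higher numbers stand for an effect only at larger amounts of compound and lower numbers for an effect already at smaller amounts), compound 3 `Cc1ccc(S(=O)(=O)N[C@@H](CC(=O)NC(C)(C)C)C(=O)NCCNS(=O)(=O)c2ccccc2)cc1` gives > 11000 nM as a limit only. Compound 1 `Cc1ccc(S(=O)(=O)N[C@@H](CC(=O)NC(C)(C)C)C(=O)NCCNC(=O)Nc2ccccc2)cc1` likewise gives > 11000 nM as a limit. Compound 2 `COc1cc(OC)cc(C(=O)NCCNC(=O)[C@H](CC(=O)NC(C)(C)C)NS(=O)(=O)c2ccc(C)cc2)c1` also gives > 11000 nM as a limit. All three thus share the limit of > 11000 nM in this assay, at which 3 of the 3 values shown sit, and no number is known for any of them. Compound 4 `Cc1ccc(S(=O)(=O)N[C@@H](CC(=O)NC(C)(C)C)C(=O)NCCNC(=O)c2cccc(C(F)(F)F)c2)cc1` carries (3-(trifluoromethyl)phenyl)carbonyl in place of phenylsulfonyl on an amine nitrogen. The measured steps bearing on this are a step that the two limits leave unreadable from compound 2 to compound 3 and a step that the two limits leave unreadable from compound 1 to compound 3 and neither offers a size. No step beyond the usual scatter is therefore expected in this assay and no direction can be given. The expected step is a step that the limit leaves unreadable from compound 3 to compound 4 by this estimate. For compound 4 the estimated value is 14000 nM with an expected range of 8000 nM to 30000 nM in this estimate.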

Compound 4, half-maximal effective concentration: > 11000 nM
Compound 4 was reported as a limit (the forecaster's own chance of this, stated with the estimate: 80%); the middle value is on the limit's open side.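

Compound 4 adds one more limit, and its steps to compound 1, compound 2 and compound 3 cannot be read in this assay: the limit of > 11000 nM in this assay, at which 4 of the 4 values shown sit.

The compounds shown leave open what number any of the four would give, and whether exchanging these groups changes it at all.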